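The source may report more compounds than this note shows. Statements on the series, on what has been measured and on what is new or still open speak of the compounds shown alone.

Compound 3 `CC(C)C1(C)NC(=O)c2sc(-c3ccncc3)cc2N1` stands at one end of the three numbers shown: in an assay for inhibition of Rho-associated protein kinase 1 (Homo sapiens), read by TR-FRET, with stated times of 5 min and 2 h (on this read-out higher numbers stand for weaker inhibition and lower numbers for stronger inhibition), compound 3 gives 35 nM, while compound 2 `CCC1(C)NC(=O)c2sc(-c3ccncc3)cc2N1` gives 36 nM and sits within the scatter of it, and compound 1 `Cc1n[nH]c(C)c1-c1cc2c(s1)C(=O)NC(C)(C)N2C` gives 2100 nM, far higher. For the measured compounds named here, the only step that bears on the change at hand is the one where a branch grows on the ring carbon: a 1.0-fold lower number from compound 2 to compound 3 (0.01 log units; within the scatter). Compound 4 `CCCC1(C)NC(=O)c2sc(-c3ccncc3)cc2N1` differs from compound 3 by propyl in place of isopropyl on a saturated ring carbon; the two share every atom and differ only in how three carbons are joined. Since the branch between compound 2 and compound 3 moved nothing, compound 4 is expected to remain close to compound 3, with a step of a 1.1-fold higher number from compound 3 to compound 4 (0.04 log units; within the scatter) in this assay. Compound 4 is therefore estimated at 38 nM, with a range from 17 nM to 85 nM.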

Compound 4, half-maximal inhibitory concentration: 33 nM
For compound 4 the middle estimate is 1.2-fold (0.06 log units) above the measured one; low and high end bracket the measured number.
By their numbers in this assay, from the lowest: compounds 4, 3 and 2 (each within the scatter of the next); then compound 1.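

In this assay, propyl in place of isopropyl on this saturated ring carbon gives a 1.1-fold lower number from compound 3 to compound 4 (0.03 log units; within the scatter), and methyl in place of hydrogen on the chain gives a 1.1-fold lower number from compound 2 to compound 4 (0.04 log units; within the scatter). So, beyond the branch already seen, neither how the chain is joined nor its extension separates these compounds here. No measurement shown offers a reason for this. Still open, on these data alone, is whether a longer chain, such as hexyl, would stay level in this assay. As far as these compounds go, an amine or a carboxylic acid at the end of the chain is equally open.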